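The compounds below may be only part of what the source reports. "The series", "measured", "known", "first", "only" and "open" are said of these compounds alone.

In an ADME assay on microsomes from liver (Homo sapiens) for metabolic stability, using NADPH, with a stated time of 30 min, in the presence of a further agent that is not named here (on this read-out lower numbers stand for a less stable compound and higher numbers for a more stable compound), three compounds have been measured. Compound 1 `O=S(=O)(c1ccc(Cl)cc1)N1CCc2n[nH]cc2C1CO` gives 84%, compound 2 `CC(C)C1Cc2n[nH]cc2CN1S(=O)(=O)c1ccc(Cl)cc1` gives 5%, and compound 3 `CC[C@H]1Cc2n[nH]cc2[C@@H](c2ccc(Cl)cc2)N1S(=O)(=O)c1ccc(Cl)cc1` gives 10%. Compound 2 thus shows the lowest of the three numbers, though the value of compound 3 lies within the scatter of it, while compound 1 stands far beyond the scatter above compound 2. Compound 4 `O=S(=O)(c1ccc(Cl)cc1)N1Cc2c[nH]nc2CC1c1ccc(F)cc1` has not yet been measured in this assay. It differs from compound 2 in one place: 4-fluorophenyl in place of isopropyl on a saturated ring carbon. Going by the values given here, no measured pair shows this change directly. Since compound 3, which also carries an aromatic ring on the saturated ring carbon, gives 10%, the step from compound 2 to compound 4 is expected to be small, a number 7 percentage points higher from compound 2 to compound 4 (within the scatter), and not beyond the scatter. Compound 4 is therefore estimated at 12%, with a range from 3% to 35%.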

Compound 4, percent of the compound remaining: 6%
The estimate for compound 4 lay 6 percentage points above the measured number; low and high end bracket the measured number.
By their numbers in this assay, from the lowest: compounds 2, 4 and 3 (each within the scatter of the next); then compound 1.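

In this assay the exchange of isopropyl for 4-fluorophenyl on this saturated ring carbon can now be read directly, and it gives a number 1 percentage points higher from compound 2 to compound 4 (within the scatter). A larger group with an aromatic ring at this position therefore leaves the read-out as low as isopropyl did. Nothing available here explains this result. The compounds shown leave open whether a primary amine or a carboxylic acid on this ring carbon would move the number beyond the scatter.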